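Selenocyanate chain variation on a shared quinazoline-free core

This account rests on a few compounds, and the source may have more. Where it says the series, first, only, none or still open, it means among the compounds named here.

Compound 1: `COc1ccc(N(C)c2nc(C)nc3ccccc23)cc1C(=O)NCC[Se]C#N` — 561 nM
Compound 2: `COc1ccc(N(C)c2nc(C)nc3ccccc23)cc1C(=O)OCCCCCC[Se]C#N` — 1050 nM
Compound 3: `COc1ccc(N(C)c2nc(C)nc3ccccc23)cc1C(=O)OCCCCC[Se]C#N` — 714 nM

In a functional assay on LoVo cells (Homo sapiens) for inhibition, read by MTT assay, with a stated time of 48 h (on this read-out higher numbers stand for weaker inhibition and lower numbers for stronger inhibition), compound 1 gives the lowest of the three numbers, but its two neighbours sit close: a 1.3-fold higher number from compound 1 to compound 3 (0.10 log units; within the scatter) and a 1.9-fold higher number from compound 1 to compound 2 (0.27 log units; within the scatter). Between the two esters, a 1.5-fold lower number from compound 2 to compound 3 (0.17 log units; within the scatter). All three compounds therefore lie within the usual scatter of one another, and no ordering can be read from them.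

Compound 4, `COc1ccc(N(C)c2nc(C)nc3ccccc23)cc1OCCCCC[Se]C#N`, is not yet measured. It differs from compound 1 in this way: a group of 9 heavy atoms (6 carbon, 1 nitrogen, 1 oxygen, 1 selenium; no ring) in place of a group of 8 heavy atoms (4 carbon, 2 nitrogen, 1 oxygen, 1 selenium; no ring), on an aromatic carbon. The carbonyl is gone, and the six-carbon chain carrying the selenocyanate now sits directly on the aromatic carbon, ortho to a methoxy group and meta to a large group.

Within the data shown here, none of the measured steps exchanges the carbonyl itself, so no step bears directly on this change. What the measured steps do show is that swapping the amide-linked short chain for ester-linked chains of five or six carbons moved the number only within the scatter. On that basis the step from compound 1 to compound 4 is expected to be small as well, estimated at a 1.2-fold higher number from compound 1 to compound 4 (0.10 log units; within the scatter). Compound 4 is therefore estimated at 700 nM, with a range from 250 nM to 2000 nM.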

Compound 4, half-maximal inhibitory concentration: 5210 nM
Compound 4: the middle estimate sits 7.4-fold (0.87 log units) below what was measured; measured number above the stated range.
By their numbers in this assay, from the lowest: compounds 1, 3 and 2 (each within the scatter of the next); then compound 4.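

In this assay, among these compounds, this change gives the only step of the set that lies beyond the scatter, a 9.3-fold higher number from compound 1 to compound 4 (0.97 log units; beyond the scatter), so the link between the aromatic carbon and the selenocyanate chain matters here in a way that the amide and ester variations did not show. The amide hydrogen is also absent from compound 2 and compound 3, whose steps from compound 1 stay within the scatter, which leaves the missing carbonyl as what sets compound 4 apart from the other three; compound 3, with the same chain held through a carbonyl, gives 714 nM, against compound 4 at 5210 nM. Nothing available explains why the number is higher for compound 4.

The compounds shown leave open whether this higher number holds for a longer chain or a shorter chain on the same oxygen link. They also leave open how an amine link in place of that oxygen, or a carboxylic acid in place of the selenocyanate, would read in this assay.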